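A few compounds are considered here, and "the series" means these few. Any claim that something is new, unique, unknown or untested is made for them only; others in the source may bear on it.

Working notes on the series, read in a functional assay on NCI-H460 cells (Homo sapiens) for inhibition, read by MTT assay, with a stated time of 72 h; a lower number here means a stronger inhibitor, a higher number a weaker inhibitor. Compound 1 (`COc1cc(NC(C)CCCNC(=O)Nc2cccc(Cl)c2)c2ncccc2c1`) gives 37000 nM and compound 2 (`COc1cc(NC(C)CCCNC(=O)Nc2ccc(F)cc2)c2ncccc2c1`) gives 26000 nM. Among the compounds with values here, these are the only two numbers so far, and compound 2 stands level with compound 1, with a 1.4-fold lower number from compound 1 to compound 2 (0.15 log units; within the scatter). That step only exchanges 3-chlorophenyl for 4-fluorophenyl on an amide-type nitrogen.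

Compound 3 (`COc1cc(NC(C)CCCNC(=O)NNC(=O)Nc2ccc(Br)cc2)c2ncccc2c1`) differs from compound 2 as follows: ((4-bromophenyl)carbamoyl)amino in place of 4-fluorophenyl on an amide-type nitrogen. Within the data shown here, no measured step covers a change of this kind, so the data give no direction for it and the range must stay wide. The expectation therefore stays anchored on compound 2 at 26000 nM, with no shift beyond the scatter foreseen. The expected change is a 1.3-fold lower number from compound 2 to compound 3 (0.11 log units; within the scatter). For compound 3 the estimated value is 20000 nM, with an expected range of 6000 nM to 60000 nM.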

Compound 3, half-maximal inhibitory concentration: 27000 nM
Estimate against measurement, compound 3: 1.4-fold (0.13 log units) below; measured number inside the range.
By their numbers in this assay, from the lowest: compounds 2, 3 and 1 (each within the scatter of the next).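

On the amide-type nitrogen, ((4-bromophenyl)carbamoyl)amino in place of the directly attached aryl groups leaves the read-out in this assay level, with a 1.0-fold higher number from compound 2 to compound 3 (0.02 log units; within the scatter) and a 1.4-fold lower number from compound 1 to compound 3 (0.14 log units; within the scatter). Against 4-fluorophenyl, this position therefore takes a group of 11 heavy atoms instead of 7, with 2 hydrogen-bond donors and 1 hydrogen-bond acceptor instead of none, and no step beyond the scatter appears. No measurement available here accounts for this result.

From the compounds shown here alone, whether anything at this position can move the number beyond the scatter stays open, as all three compounds lie within the scatter of one another. A simple amine, a carboxylic acid or a short alkyl chain on this nitrogen would test whether an aryl-bearing group is needed at all.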